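A Smaller Arm on the Sulfonamide Nitrogen

The source may hold more compounds than are shown below. What is called first, only, known or untested is meant among the compounds shown, and "the series" means these compounds.

Measured compounds:
compound 1, `CC(C)NC(=O)N1CCC(CN(C2Cc3cc(C#N)ccc3N(Cc3cncn3C)C2)S(=O)(=O)c2ccccn2)CC1`: 0.6 10^-6 cm/s
compound 2, `Cn1cncc1CN1CC(N(CC2CCN(C(=O)Nc3ccc(Br)cc3)CC2)S(=O)(=O)c2ccccn2)Cc2cc(C#N)ccc21`: 0.6 10^-6 cm/s

In an ADME assay on Caco-2 cells (Homo sapiens) for permeability, in the apical to basolateral direction (a lower number here means that the compound crosses the layer more slowly, a higher number that the compound crosses the layer faster), compound 1 gives 0.6 10^-6 cm/s, and compound 2 gives 0.6 10^-6 cm/s. Within the data shown here, the one measured step, no change at the digits printed from compound 1 to compound 2 (within the scatter), shows that exchanging the substituent on the amide-type nitrogen left the read-out where it was. Compound 1 thus stands level with compound 2 at the digits shown, and both sit at a low value.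

Compound 3, `Cc1noc(C)c1CN(C1Cc2cc(C#N)ccc2N(Cc2cncn2C)C1)S(=O)(=O)c1ccccn1`, is not yet measured. Its difference from compound 1 is 3,5-dimethyl-1,2-oxazol-4-yl in place of 1-(isopropylcarbamoyl)piperidin-4-yl on a saturated chain carbon bound to a sulfonamide nitrogen. This change is of another kind than the measured step: it does not vary the amide substituent but removes the whole 1-(isopropylcarbamoyl)piperidin-4-yl group and puts the 3,5-dimethyl-1,2-oxazol-4-yl group in its place. The step from compound 1 to compound 2 therefore bears only weakly on it, and it gives no direction. With nothing measured on this kind of change, the estimate for compound 3 is 1.5 10^-6 cm/s with a range of 0.4 10^-6 cm/s to 6 10^-6 cm/s, an expected step of a 2.5-fold higher number from compound 1 to compound 3 (0.40 log units; beyond the scatter), leaning upward but uncertain.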

Compound 3, apparent permeability: 8 10^-6 cm/s
Compound 3: the middle estimate sits 5.3-fold (0.73 log units) below what was measured; measured number above the stated range.
By their numbers in this assay, from the lowest: compounds 1 and 2 (each within the scatter of the next); then compound 3.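

The arm on the saturated chain carbon bound to a sulfonamide nitrogen proves to matter in this assay: the exchange on the amide-type nitrogen had left the number where it was, no change at the digits printed from compound 1 to compound 2 (within the scatter), whereas replacing the whole arm gives a 13-fold higher number from compound 1 to compound 3 (1.12 log units; beyond the scatter). This single step changes several things at once, since 1-(isopropylcarbamoyl)piperidin-4-yl, with 12 heavy atoms and 1 hydrogen-bond donor, gives way to 3,5-dimethyl-1,2-oxazol-4-yl, with 7 heavy atoms and 0 hydrogen-bond donors, and a six-membered non-aromatic ring gives way to a five-membered aromatic one, so the rise cannot be assigned to any one of these differences. Nothing among the data offered here accounts for the rise.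

The compounds shown leave open which of these differences carries the step, and a plain cyclohexyl or a piperidin-4-yl with an acetyl group on its nitrogen at the same place would help to separate them. They also leave open whether the two methyl groups matter, which the unsubstituted 1,2-oxazol-4-yl would address.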